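Swapping a Propyl Chain for Phenoxy on a Weak Inhibitor

This account rests on a few compounds, and the source may have more. Where it says the series, first, only, none or still open, it means among the compounds named here.

Three compounds have been measured in a functional assay on brain (Rattus norvegicus, strain Wistar) for inhibition; a lower number here means a stronger inhibitor, a higher number a weaker inhibitor:

Compound 1, `CCCc1ccc(-c2c(C)[nH]c(=O)n2C)cc1`, gives 21500 nM.
Compound 2, `CCCc1ccc(-c2c(C)[nH]c(=O)n2C2CCCCC2)cc1`, gives 13900 nM.
Compound 3, `CCCCCCCCCCCCCCc1ccc(-c2c(C)[nH]c(=O)n2C2CCCCC2)cc1`, reaches only the limit of the assay at > 100000 nM.

Compound 2 holds the lowest of the two real numbers, yet the step of a 1.5-fold lower number from compound 1 to compound 2 (0.19 log units; within the scatter) lies within the scatter, so compound 1 and compound 2 cannot be told apart. Compound 3 sits at a limit (the limit of > 100000 nM in this assay, at which 1 of the 3 values shown sits), so for it only a bound is known.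

Compound 4, `Cc1[nH]c(=O)n(C2CCCCC2)c1-c1ccc(Oc2ccccc2)cc1`, has not yet been measured. It differs from compound 2 by phenoxy in place of propyl on an aromatic carbon. For the measured compounds named here, the one measured step that touches the same position is an at least 7.1-fold higher number from compound 2 to compound 3 (0.85 log units; beyond the scatter), where a far longer chain at this place made the compound fall to the limit. Phenoxy is larger than propyl but much shorter than that chain, so a weakening smaller than that step, or none beyond the scatter, is expected. Going by the values given here, no measured step on the shared core shows a gain at this position.

Compound 4 is therefore estimated at 25000 nM, between 8000 nM and 100000 nM, which would mean an expected step of a 1.8-fold higher number from compound 2 to compound 4 (0.25 log units; within the scatter).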

Compound 4, half-maximal inhibitory concentration: 7900 nM
Compound 4: middle estimate off by 3.2-fold (0.50 log units), on the high side; the whole stated range lies above it.
By their numbers in this assay, from the lowest: compounds 4, 2 and 1 (each within the scatter of the next, the first and the last beyond it). At a limit, above all of these: compound 3.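

In this assay, the change at this position gives a 1.8-fold lower number from compound 2 to compound 4 (0.25 log units; within the scatter), so a propyl chain can give way to phenoxy, which brings in an aromatic ring and an oxygen, without a change beyond the scatter. For the compounds shown here, until now, the only other change at this place was the far longer chain of compound 3, and compound 3 stands at a limit of the assay, > 100000 nM. A larger group here therefore does not always send a compound to the limit, although phenoxy brings no gain that can be told from the scatter either, and nothing measured here explains why these two large groups part ways.

The compounds shown leave open whether another group at this position, such as an amine, a carboxylic acid or a benzyloxy group, would move the number beyond the scatter. They also leave open how a hexyl or octyl chain would fare compared with propyl and the far longer chain of compound 3, and whether phenoxy would give a similar number with methyl in place of cyclohexyl on the aromatic nitrogen.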